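Replacing One Side Group: Compound 3 to Compound 4

The source may hold more compounds than are shown below. What is called first, only, known or untested is meant among the compounds shown, and "the series" means these compounds.

- compound 1 `COc1ccc(Cn2cc(C3(O)C=CC(=O)C=C3)nn2)cc1` gives 450 nM
- compound 2 `O=C1C=CC(O)(c2cc3ccccc3n2S(=O)(=O)c2ccccc2)C=C1` gives 110 nM
- compound 3 `CCOC(=O)Nc1ccc(S(=O)(=O)n2c(C3(O)C=CC(=O)C=C3)cc3ccccc32)cc1` gives 86 nM

These three numbers all come from an ADME assay on MRC5 cells (Homo sapiens) for cytotoxicity, read by fluorescence and resazurin assay, with a stated time of 3 days (a higher number here means that more compound is needed for the effect, a lower number that less compound is needed), where a lower number means that less compound is needed for the effect. Compound 3 and compound 2 lie within the scatter of each other, and compound 1 stands well apart from compound 3 with a higher number.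

Compound 4 `COC(=O)CCc1ccc(S(=O)(=O)n2c(C3(O)C=CC(=O)C=C3)cc3ccccc32)cc1` has not yet been measured. It keeps the core of compound 3 and has 2-(methoxycarbonyl)ethyl in place of (ethoxycarbonyl)amino on an aromatic carbon.

For the measured compounds named here, only one measured step touches this place: a 1.3-fold lower number from compound 2 to compound 3 (0.11 log units; within the scatter). That step put (ethoxycarbonyl)amino in place of hydrogen on an aromatic carbon, and it stayed within the scatter. Going by the values given here, compound 1 differs from the others in more than one place, so it supplies no step here. Among the compounds with values here, no measured compound carries 2-(methoxycarbonyl)ethyl, so the evidence is indirect. Since compound 3 barely differs from compound 2 in this assay, with the step given above as the only guide, no change beyond the scatter is expected, in either direction.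

The expected step is a 1.0-fold higher number from compound 3 to compound 4 (0.02 log units; within the scatter). Compound 4 is estimated at 90 nM, with an expected range from 40 nM to 190 nM.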

Compound 4, half-maximal effective concentration: 280 nM
Compound 4: middle estimate off by 3.1-fold (0.49 log units), on the low side; measured number outside the range, above it.
By their numbers in this assay, from the lowest: compounds 3 and 2 (each within the scatter of the next); then compounds 4 and 1 (each within the scatter of the next).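

In this assay, for the compounds shown here, the place on the aromatic carbon para to a large group turns out to matter: replacing (ethoxycarbonyl)amino with 2-(methoxycarbonyl)ethyl gives a 3.3-fold higher number from compound 3 to compound 4 (0.51 log units; beyond the scatter), whereas the only earlier step here stayed within the scatter. Starting from hydrogen tells the same story, since 2-(methoxycarbonyl)ethyl gives a 2.5-fold higher number from compound 2 to compound 4 (0.41 log units; beyond the scatter) while (ethoxycarbonyl)amino gives a 1.3-fold lower number from compound 2 to compound 3 (0.11 log units; within the scatter), so the outcome depends on which group enters and not merely on hydrogen being replaced. The two groups each have 6 heavy atoms, no ring and no net charge, and (ethoxycarbonyl)amino has a nitrogen and 1 hydrogen-bond donor where 2-(methoxycarbonyl)ethyl has none, but nothing available links the step to this difference or to any other.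

From the compounds shown here alone, it remains open whether a plain amine on this aromatic carbon, or a carboxylic acid in place of the methoxycarbonyl end of the chain, would give a number closer to compound 3 or to compound 4. Going by these compounds, a longer chain is equally open, as is whether this step would carry over to a different core such as that of compound 1.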